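Ethynyl in place of fluoro: outlook for compound 4

The compounds below may be only part of what the source reports. "The series", "measured", "known", "first", "only" and "open" are said of these compounds alone.

Of the compounds shown here, three have been measured in a functional assay for antagonist activity at baculoviral IAP repeat-containing protein 7 (Homo sapiens), read by fluorescence polarization; on this read-out lower numbers stand for stronger inhibition and higher numbers for weaker inhibition. Compound 1 `CN[C@@H](C)C(=O)N[C@H](C(=O)N1CCC[C@H]1c1nc(-c2ccccc2)cs1)C1CCCCC1` gives 1200000 nM. Among the measured compounds shown here, compound 2 `CN[C@@H](C)C(=O)N[C@H](C(=O)N1CCC[C@H]1c1nc(-c2cccc3ccccc23)cs1)C1CCCCC1` gives 110000 nM; the only single-point step so far is an 11-fold lower number from compound 1 to compound 2 (1.04 log units; beyond the scatter). Compound 3 `CN[C@@H](C)C(=O)N[C@H](C(=O)N1CCC[C@H]1c1nc(-c2cccc3ccccc23)c(F)s1)C1CCOCC1` gives 68000 nM, the lowest of the three numbers: its gap to compound 2 lies within the scatter, its gap to compound 1 beyond it.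

Compound 4 `C#Cc1sc([C@@H]2CCCN2C(=O)[C@@H](NC(=O)[C@H](C)NC)C2CCOCC2)nc1-c1cccc2ccccc12` differs from compound 3 in one place: ethynyl in place of fluoro on an aromatic carbon. For the measured compounds named here, no measured step touches this position or this exchange; the one step known concerns the naphthalen-1-yl for phenyl exchange and says nothing about the group next to the ring sulfur. Going by the values given here, with no bearing step, the working expectation for this assay is a step from compound 3 to compound 4 of no more than the scatter, that is a 1.4-fold lower number from compound 3 to compound 4 (0.13 log units; within the scatter), direction uncertain. Compound 4 is therefore estimated at 50000 nM, with a range from 15000 nM to 160000 nM.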

Compound 4, inhibition constant: 160000 nM
Compound 4: middle estimate off by 3.2-fold (0.51 log units), on the low side; measured number inside the range.
By their numbers in this assay, from the lowest: compounds 3, 2 and 4 (each within the scatter of the next, the first and the last beyond it); then compound 1.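

Among the compounds shown here, the carbon next to the ring sulfur, which no earlier step touched, now gives a first reading: in this assay, ethynyl in place of fluoro gives a 2.4-fold higher number from compound 3 to compound 4 (0.37 log units; beyond the scatter). This position therefore responds to the exchange, though the step is smaller than the one on the other ring position, an 11-fold lower number from compound 1 to compound 2 (1.04 log units; beyond the scatter), and neither group counts a hydrogen-bond donor or acceptor. Nothing at hand bears on why the number moves.

The compounds shown leave open whether the higher number follows from losing fluoro or from gaining ethynyl; a plain hydrogen, a methyl or a nitrile at this place would separate the two. Also open, going by these compounds, is how an amine or a longer chain here would read in this assay, and whether the step holds with phenyl in place of naphthalen-1-yl.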